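This account rests on a few compounds, and the source may have more. Where it says the series, first, only, none or still open, it means among the compounds named here.

Measured compounds:
- compound 1, `COc1ccc(C2=NN(c3ccccc3)C(c3ccc(C)cc3)C2S(=O)(=O)CC2=NCCO2)cc1`: 59.1%
- compound 2, `COc1ccc(C2=NN(c3ccccc3)C(c3ccc(C)cc3)C2S(=O)(=O)CC2=NCCS2)cc1`: 39.4%
- compound 3, `O=S(=O)(CC1=NCCS1)C1=NNCC1c1ccc(Cl)cc1`: "not active" (no number reported)

In a functional assay, read by Griess assay, with a stated time of 150 min, tested at 50 ug/mL (a higher number here means a stronger effect of the compound at the concentration tested, a lower number a weaker effect), compound 1 gives 59.1% and compound 2 gives 39.4%. The two share one core and differ by a single change, (a group of 5 heavy atoms (3 carbon, 1 nitrogen, 1 oxygen; one five-membered non-aromatic ring with 2 hetero atoms) in place of a group of 5 heavy atoms (3 carbon, 1 nitrogen, 1 sulfur; one five-membered non-aromatic ring with 2 hetero atoms), on a saturated chain carbon bound to a sulfonyl sulfur); this change brings a number 19.7 percentage points higher from compound 2 to compound 1 (beyond the scatter). Compound 3 has a different core, and in this assay compound 3 is reported as "not active" (no number reported). The difference between the core of compound 3 and that of compound 2 is not broken down here.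

The unmeasured compound 4, `O=S(=O)(CC1=NCCO1)C1=NNCC1c1ccc(Cl)cc1`, is compound 3 with the same change applied: a group of 5 heavy atoms (3 carbon, 1 nitrogen, 1 oxygen; one five-membered non-aromatic ring with 2 hetero atoms) in place of a group of 5 heavy atoms (3 carbon, 1 nitrogen, 1 sulfur; one five-membered non-aromatic ring with 2 hetero atoms), on a saturated chain carbon bound to a sulfonyl sulfur. Since it is the same change at the same place as from compound 2 to compound 1, a step of similar size in this assay may be expected, but it starts from a compound that showed no activity, so the outcome is uncertain. For compound 4 in this assay a weak read-out is estimated, around 18%, with an expected range from 0% to 42%, and it may again be reported only as not active.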

Compound 4, a percentage reported as activity, at one concentration (the size of the read-out at that concentration, not a potency): "not active" (no number reported)
No number was reported for compound 4; no gap can be computed for the estimate.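

In this assay compound 3 and compound 4 are both reported only as not active, with no number, so no new step can be read between them. Nothing available here offers a reason for this. On these data alone, it remains open whether the ring change that separates compound 2 from compound 1 has any effect on the core of compound 3.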